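A few compounds are considered here, and "the series" means these few. Any claim that something is new, unique, unknown or untested is made for them only; others in the source may bear on it.

Measured so far in an ADME assay on liver for metabolic stability, with Liver microsome (Homo sapiens) as the target, using microsomes; on this read-out lower numbers stand for slow clearance and higher numbers for fast clearance:
- compound 1 `C=CC(=O)Nc1cccc(-n2c(-c3nc(-c4cnn(C5CCN(C)CC5)c4)cnc3N)nc3ccccc32)c1`: 120 mL.min-1.g-1
- compound 2 `C=CC(=O)Nc1cccc(-n2c(-c3nc(-c4cnn(C)c4)cnc3N)nc3ccccc32)c1`: 24 mL.min-1.g-1

Compound 2 has the lowest number of the two; the nearest is compound 1, where a 5.0-fold lower number from compound 1 to compound 2 (0.70 log units; beyond the scatter) separates the pair.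

Compound 3 `C=CC(=O)Nc1cccc(-n2c(-c3nc(-c4cnn(CCN5CCN(C)CC5)c4)cnc3N)nc3ccccc32)c1` is not yet measured in this assay. It differs from compound 2 by (4-methylpiperazin-1-yl)methyl in place of hydrogen on a saturated chain carbon bound to an aromatic nitrogen.

For the measured compounds named here, the only measured step that bears on this change is a 5.0-fold lower number from compound 1 to compound 2 (0.70 log units; beyond the scatter), in which a ring-bearing group on the aromatic nitrogen of compound 1 was replaced by methyl. Compound 3 moves in the opposite direction, with a ring-bearing group again attached at that nitrogen through a saturated chain. The expected step is therefore upward, of similar size to that precedent, though it rests on a single pair.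

The estimate for compound 3 in this assay is 70 mL.min-1.g-1, within a range of 30 mL.min-1.g-1 to 180 mL.min-1.g-1, which means an expected step of a 2.9-fold higher number from compound 2 to compound 3 (0.46 log units; beyond the scatter).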

Compound 3, intrinsic clearance in microsomes: 60 mL.min-1.g-1
For compound 3 the middle estimate is 1.2-fold (0.07 log units) above the measured one; low and high end bracket the measured number.
By their numbers in this assay, from the lowest: compound 2; then compounds 3 and 1 (each within the scatter of the next).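

Working from this assay, compound 3 gives a second ring-bearing group on the aromatic nitrogen that stands above the methyl of compound 2 (a 2.5-fold higher number from compound 2 to compound 3 (0.40 log units; beyond the scatter)), so the direction seen with the 1-methylpiperidin-4-yl group of compound 1 also holds for a 2-(4-methylpiperazin-1-yl)ethyl group, which reaches the ring through a saturated chain. The two ring-bearing groups cannot be told apart on this read-out (a 2.0-fold lower number from compound 1 to compound 3 (0.30 log units; within the scatter)), so these compounds give no sign that the chain or the second ring nitrogen matters here. Nothing available explains either step.

Still open, on these data alone, is whether the ring is needed at all, which a 2-(dimethylamino)ethyl group could test, or whether the ring nitrogen matters, which a 2-morpholinoethyl or 2-hydroxyethyl group could test. A longer chain to the same 4-methylpiperazine ring also remains to be read.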